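This account rests on a few compounds, and the source may have more. Where it says the series, first, only, none or still open, it means among the compounds named here.

The compounds here share one core and differ in the group on the amide-type nitrogen and in the aryl group on the ring. Compound 1 `C=CC1=C(C(=O)NCCCCC)C(c2ccc(OC)cc2)OC1` was tested in a functional assay on SW480 cells (Homo sapiens) for cytotoxicity, read by MTT assay, with a stated time of 24 h; a lower number here means a stronger inhibitor, a higher number a weaker inhibitor; compound 1 gives > 100000 nM, which is a limit of the assay and not a number. Compound 3 `C=CC1=C(C(=O)Nc2ccccc2OC)C(c2ccc(OC)cc2)OC1` gives > 100000 nM in this assay, again a limit. Compound 2 `C=CC1=C(C(=O)Nc2ccccc2)C(c2ccc(Cl)c(Cl)c2)OC1` gives > 100000 nM in this assay, also a limit. For the measured compounds named here, the only step between measured compounds, a step that the two limits leave unreadable from compound 1 to compound 3, cannot be read because the limit of > 100000 nM in this assay, at which 3 of the 3 values shown sit, covers both of its ends.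

Compound 4 `C=CC1=C(C(=O)NCCC)C(c2ccc(Cl)c(Cl)c2)OC1` differs from compound 2 by propyl in place of phenyl on an amide-type nitrogen. Going by the values given here, no measured step bears on this change, since every value so far is a limit. Nothing in the data points to a move in either direction beyond the scatter, so the step from compound 2 to compound 4 is expected to be small, as a step that the limit leaves unreadable from compound 2 to compound 4 means. Compound 4 is therefore estimated at 150000 nM, with a range from 50000 nM to 500000 nM, and most likely it too is reported only as a limit.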

Compound 4, half-maximal inhibitory concentration: > 100000 nM
Compound 4 ended at the assay's limit; the forecaster's own chance of this, stated with the estimate: 85%; the middle value is on the limit's open side.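

Swapping phenyl for propyl gives no readable step from compound 2 to compound 4, because both values are limits of the assay and not numbers: the limit of > 100000 nM in this assay, at which 4 of the 4 values shown sit. The compounds shown leave open which change to the amide-type nitrogen group or the aryl group, if any, would give a readable potency.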